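This account rests on a few compounds, and the source may have more. Where it says the series, first, only, none or still open, it means among the compounds named here.

In a functional assay on HT-29 cells (Homo sapiens) for inhibition, read by CCK-8 assay, with a stated time of 24 h (a higher number here means a weaker inhibitor, a lower number a stronger inhibitor), compound 1 `O=C1Nc2ccc(F)cc2/C1=C/c1ccc(-c2cn(-c3ccccc3F)nn2)cc1` gives 8980 nM and compound 2 `O=C1Nc2ccc(F)cc2/C1=C/c1ccc(-c2cn(-c3ccccc3Cl)nn2)cc1` gives 5950 nM. These two values lie within the scatter of each other, so compound 2 cannot be ranked apart from compound 1. Compound 3 `N#Cc1cccc(-n2cc(-c3ccc(/C=C4\C(=O)Nc5ccc(F)cc54)cc3)nn2)c1` shares their core and differs from compound 2 in one place, with 3-cyanophenyl in place of 2-chlorophenyl on an aromatic nitrogen. Going by the values given here, the only measured step that bears on this is a 1.5-fold lower number from compound 1 to compound 2 (0.18 log units; within the scatter), for chloro in place of fluoro on an aromatic carbon, and it stays within the scatter. Neither measured compound carries a 3-cyanophenyl, so that step offers no direction for the new group. No step beyond the scatter is expected in this assay, and the expected change is a 1.0-fold higher number from compound 2 to compound 3 (0.00 log units; within the scatter). Compound 3 is estimated at 6000 nM, with an expected range from 2500 nM to 15000 nM.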

Compound 3, half-maximal inhibitory concentration: > 20000 nM
Compound 3 ended at the assay's limit (the forecaster's own chance of this, stated with the estimate: 10%); at least 3.3-fold (0.52 log units) between middle value and limit.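

Changing the aryl group on the aromatic nitrogen can shift the result in this assay, which the halogen swap between compounds 1 and 2 did not show, as that step stayed within the scatter. Putting 3-cyanophenyl in place of 2-chlorophenyl gives an at least 3.3-fold higher number from compound 2 to compound 3 (0.52 log units; beyond the scatter), and putting it in place of 2-fluorophenyl gives an at least 2.2-fold higher number from compound 1 to compound 3 (0.34 log units; beyond the scatter), so both steps point the same way and lie beyond the scatter. The reading for compound 3 is a limit and not a number, so these steps give only the smallest size of the change: the limit of > 20000 nM in this assay, at which 1 of the 3 values shown sits.

The compounds shown leave open whether the loss of the halogen or the entry of the nitrile accounts for the step, since the two change together here. They also leave open how a plain phenyl or a methoxyphenyl on this nitrogen would read.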